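Guanidine in Place of Dimethylamino on the Propoxy Chain

The source may report more compounds than this note shows. Statements on the series, on what has been measured and on what is new or still open speak of the compounds shown alone.

Compound 1 `CN(C)CCCOc1ccc(CN(C)c2nc3ccc(Oc4ccc(C(F)(F)F)cc4)cc3s2)cc1`: 54000 nM
Compound 2 `CN(Cc1ccc(OCCCN)cc1)c1nc2ccc(Oc3ccccc3)cc2s1`: 95000 nM
Compound 3 `CN(C)CCCOc1ccc(CN(C)c2nc3ccc(Oc4ccc(C#N)cc4)cc3s2)cc1`: 64000 nM

In an assay on cells for inhibition of Voltage-dependent T-type calcium channel subunit alpha-1H (Homo sapiens), read by FLIPR and calcium flux, with stated times of 600 s and 300 s (a lower number here means a stronger inhibitor, a higher number a weaker inhibitor), compound 1 gives the lowest of the three numbers, but compound 3 lies within the scatter of it, as a 1.2-fold higher number from compound 1 to compound 3 (0.07 log units; within the scatter) shows, and the value of compound 2 also falls within the scatter of compound 1. Compound 4 `CN(Cc1ccc(OCCCNC(=N)N)cc1)c1nc2ccc(Oc3ccc(C(F)(F)F)cc3)cc2s1` differs from compound 1 in one place: a group of 4 heavy atoms (1 carbon, 3 nitrogen; no ring) in place of a group of 3 heavy atoms (2 carbon, 1 nitrogen; no ring), on a saturated chain carbon, three bonds along the chain from an oxygen on an aromatic ring. Within the data shown here, no measured step alters this end of the chain on its own; compound 2 carries another group at the same place but differs elsewhere as well, so its value offers only a loose guide. The change is therefore expected to give a step of a 1.3-fold higher number from compound 1 to compound 4 (0.11 log units; within the scatter), not beyond the scatter. Compound 4 is estimated at 70000 nM, with a range from 25000 nM to 200000 nM.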

Compound 4, half-maximal inhibitory concentration: 212000 nM
For compound 4 the middle estimate is 3.0-fold (0.48 log units) below the measured one, outside the stated range (above it).
By their numbers in this assay, from the lowest: compounds 1, 3 and 2 (each within the scatter of the next); then compound 4.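

At this end of the chain, the position on a saturated chain carbon, three bonds along the chain from an oxygen on an aromatic ring, proves sensitive to change in this assay: the new group gives a 3.9-fold higher number from compound 1 to compound 4 (0.59 log units; beyond the scatter). The earlier single change on an aromatic carbon, a 1.2-fold higher number from compound 1 to compound 3 (0.07 log units; within the scatter), had shown no such separation. Nothing measured here accounts for this step.

As far as these compounds go, how a urea, a carboxylic acid or a longer chain would read at this place remains open, as does whether the step would recur with the cyano group of compound 3.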